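Chloro in Place of Fluoro: Compound 3 to Compound 4

A few compounds are considered here, and "the series" means these few. Any claim that something is new, unique, unknown or untested is made for them only; others in the source may bear on it.

Three compounds share a core and differ only in the group carried on an amine nitrogen in a ring. In an assay on CHO cells for displacement of a labelled ligand from 5-hydroxytryptamine receptor 7 (Homo sapiens) (a higher number here means a weaker inhibitor, a lower number a stronger inhibitor), compound 1 `CCC1(CCCCN2CCN(c3ccc(OC)cc3)CC2)C(=O)Nc2ccccc21` gives 25.4 nM. Compound 2 `CCC1(CCCCN2CCN(c3ccccc3OC)CC2)C(=O)Nc2ccccc21` gives 5.38 nM in this assay, which is a 4.7-fold lower number from compound 1 to compound 2 (0.67 log units; beyond the scatter). Compound 3 `CCC1(CCCCN2CCN(c3ccc(F)c(Cl)c3)CC2)C(=O)Nc2ccccc21` gives 0.6 nM in this assay, a 42-fold lower number from compound 1 to compound 3 (1.63 log units; beyond the scatter) and a 9.0-fold lower number from compound 2 to compound 3 (0.95 log units; beyond the scatter); it therefore holds the lowest number of the three, beyond the scatter from both of the others.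

Compound 4 `CCC1(CCCCN2CCN(c3ccc(Cl)c(Cl)c3)CC2)C(=O)Nc2ccccc21` differs from compound 3 in one place: chloro in place of fluoro on an aromatic carbon. Within the data shown here, none of the measured steps exchanges one halogen for another on this ring; each of them replaces the whole substitution pattern of the ring, and the 3-chloro-4-fluorophenyl of compound 3 produced the two largest changes seen. Those steps show that the choice of group on this ring moves the number a great deal, yet they give no direction for a chloro in place of a fluoro. The step expected in this assay is accordingly small: no change at the digits printed from compound 3 to compound 4 (within the scatter), likely within the scatter. Compound 4 is expected to give about 0.6 nM in this assay, with a range from 0.2 nM to 2 nM.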

Compound 4, inhibition constant: 0.63 nM
Beside the measured number, compound 4's estimate is 1.1-fold (0.02 log units) below it, within the range that was stated.
By their numbers in this assay, from the lowest: compounds 3 and 4 (each within the scatter of the next); then compound 2; then compound 1.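

In this assay, exchanging fluoro for chloro on this aromatic carbon, para to a large group and ortho to a chloro group, gives a 1.1-fold higher number from compound 3 to compound 4 (0.02 log units; within the scatter), so this pair cannot be told apart. The earlier steps shown here each replaced the whole substitution pattern of the ring, whereas this one shows that, with the other chloro group kept, either halogen can stand here and the number stays at the low end of the series. The 3,4-dichlorophenyl group also holds the distance from the two methoxyphenyl compounds, with an 8.5-fold lower number from compound 2 to compound 4 (0.93 log units; beyond the scatter) and a 40-fold lower number from compound 1 to compound 4 (1.61 log units; beyond the scatter), and nothing measured here addresses why the two halogens read alike.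

The compounds shown leave open how a bromo, a methyl or a trifluoromethyl group would read at this position. They also leave open whether fluoro and chloro would still read alike on a ring without the other chloro group, as in a 4-fluorophenyl and a 4-chlorophenyl pair.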